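This account rests on a few compounds, and the source may have more. Where it says the series, first, only, none or still open, it means among the compounds named here.

In a functional assay on K562 cells (Homo sapiens) for inhibition, read by MTT assay, with a stated time of 48 h (on this read-out lower numbers stand for stronger inhibition and higher numbers for weaker inhibition), compound 1 `CC(=O)Nc1ccc(-c2cn([C@@H]3CN[C@H](C(=O)Nc4ccc(Cl)c(C(F)(F)F)c4)C3)nn2)cn1` gives 8980 nM and compound 2 `O=C(Nc1ccc(-c2cn([C@@H]3CN[C@H](C(=O)Nc4ccc(Cl)c(C(F)(F)F)c4)C3)nn2)cn1)C1CC1` gives 8770 nM. Exchanging methyl for cyclopropyl on the carbonyl carbon gives a 1.0-fold lower number from compound 1 to compound 2 (0.01 log units; within the scatter). Compound 3 `O=C(NC1CC1)c1cncc(-c2cn([C@@H]3CN[C@H](C(=O)Nc4ccc(Cl)c(C(F)(F)F)c4)C3)nn2)c1` has the lowest number of the three at 820 nM, and replacing the aromatic group gives an 11-fold lower number from compound 1 to compound 3 (1.04 log units; beyond the scatter) and an 11-fold lower number from compound 2 to compound 3 (1.03 log units; beyond the scatter).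

Compound 4 `Nc1n[nH]c2cc(-c3cn([C@@H]4CN[C@H](C(=O)Nc5ccc(Cl)c(C(F)(F)F)c5)C4)nn3)ccc12` carries 3-amino-1H-indazol-6-yl in place of the 5-(cyclopropylcarbamoyl)pyridin-3-yl of compound 3, on an aromatic carbon of the five-membered aromatic ring with 3 nitrogen: 3-amino-1H-indazol-6-yl in place of 5-(cyclopropylcarbamoyl)pyridin-3-yl on an aromatic carbon.

The two large steps bear most directly on this change, since they involve the same place and show that the group there can matter. For the measured compounds named here, both end at compound 3, but no measured compound carries the entering group, so the data do not fix the direction. The methyl-to-cyclopropyl step says little here.

The expected step is a 1.8-fold higher number from compound 3 to compound 4 (0.26 log units; within the scatter), leaning towards weaker inhibition. For compound 4 the estimated value is 1500 nM, with an expected range of 300 nM to 7000 nM.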

Compound 4, half-maximal inhibitory concentration: 8320 nM
For compound 4 the middle estimate is 5.5-fold (0.74 log units) below the measured one, outside the stated range (above it).
By their numbers in this assay, from the lowest: compound 3; then compounds 4, 2 and 1 (each within the scatter of the next).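

Placing 3-amino-1H-indazol-6-yl on this aromatic carbon gives a 10-fold higher number from compound 3 to compound 4 (1.01 log units; beyond the scatter) in this assay, so the low number of compound 3 does not carry over to this quite different aromatic group. The same change gives a 1.1-fold lower number from compound 2 to compound 4 (0.02 log units; within the scatter) and a 1.1-fold lower number from compound 1 to compound 4 (0.03 log units; within the scatter) and thus places the new group level with both acylaminopyridine groups, so of the four groups at this position, only the 5-(cyclopropylcarbamoyl)pyridin-3-yl of compound 3 stands apart. No measurement is available to explain this difference.

The compounds shown leave open whether the separation of compound 3 comes from its pyridine ring or its cyclopropyl amide, which a plain pyridin-3-yl group, or a carboxylic acid in place of that amide, could help to separate. They also leave open whether the same gap would appear with a different group in place of the chloro and trifluoromethyl groups on the shared core.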